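A Trifluoromethylphenyl Variant Among Three Measured Analogues

The source may report more compounds than this note shows. Statements on the series, on what has been measured and on what is new or still open speak of the compounds shown alone.

Measured so far:
compound 1 `c1ccc2c(-c3cn4ccnc4c(-c4ccc5ncn(C6CCCCC6)c5c4)n3)cccc2c1` — 36.5%
compound 2 `CC(=O)c1ccc(-c2cn3ccnc3c(-c3ccc4ncn(C5CCCCC5)c4c3)n2)cc1` — 17.9%
compound 3 `Clc1ccc(-c2cn3ccnc3c(-c3ccc4ncn(C5CCCCC5)c4c3)n2)cc1` — 24.6%

All three were tested in a functional assay on PC-3 cells (Homo sapiens) for inhibition, read by sulforhodamine B assay, with a stated time of 48 h, tested at 10 uM; on this read-out higher numbers stand for more inhibition at the one concentration tested (going by the name of the read-out) and lower numbers for less inhibition. Compound 3 stands second of the three numbers. Its nearest neighbour is compound 2: the step of a number 6.7 percentage points higher from compound 2 to compound 3 (within the scatter) lies within the scatter, so the two cannot be ordered. Its furthest is compound 1: the step of a number 11.9 percentage points lower from compound 1 to compound 3 (beyond the scatter) is a modest drop beyond the scatter, and the parallel step a number 18.6 percentage points lower from compound 1 to compound 2 (beyond the scatter) shows the same direction.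

Compound 4 `FC(F)(F)c1cccc(-c2cn3ccnc3c(-c3ccc4ncn(C5CCCCC5)c4c3)n2)c1` differs from compound 3 in one place: 3-(trifluoromethyl)phenyl in place of 4-chlorophenyl on an aromatic carbon. Going by the values given here, no measured step makes this exchange. Among the compounds with values here, the only step between two substituted phenyl groups, a number 6.7 percentage points higher from compound 2 to compound 3 (within the scatter), stayed within the scatter, whereas the larger drops came only when the naphthalen-1-yl group was replaced. On that basis compound 4 is expected to show no step beyond the scatter, a number 0.6 percentage points lower from compound 3 to compound 4 (within the scatter). The value of compound 4 in this assay is estimated at 24%, within a range from 10% to 40%.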

Compound 4, a percentage reported as inhibition, at one concentration (the size of the read-out at that concentration, not a potency): 36.5%
For compound 4 the middle estimate is 12.5 percentage points below the measured one; the measured number falls inside the stated range.
By their numbers in this assay, from the lowest: compounds 2 and 3 (each within the scatter of the next); then compounds 1 and 4 (each within the scatter of the next).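

In this assay the exchange of one substituted phenyl group for another at this position now gives a number 11.9 percentage points higher from compound 3 to compound 4 (beyond the scatter) and also a number 18.6 percentage points higher from compound 2 to compound 4 (beyond the scatter), so these exchanges can move the number beyond the scatter, which the step between compounds 2 and 3 had not shown. The naphthalen-1-yl group is also not needed for the higher number seen with compound 1: the 3-(trifluoromethyl)phenyl group gives no change at the digits printed from compound 1 to compound 4 (within the scatter) in the same assay. No measurement at hand accounts for these steps.

The compounds shown do not tell whether the trifluoromethyl group itself or its place on the phenyl ring accounts for the rise from compound 3 to compound 4. Going by these compounds, how an amine, a carboxylic acid or a methoxy group would read at this position also remains open.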